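Selenium-bearing series: expected potency of compound 4

The source may report more compounds than this note shows. Statements on the series, on what has been measured and on what is new or still open speak of the compounds shown alone.

Three compounds of the shared core have been run in a functional assay on HepG2 cells (Homo sapiens) for inhibition, read by MTT assay, with a stated time of 48 h; on this read-out lower numbers stand for stronger inhibition and higher numbers for weaker inhibition. Compound 1 `Cc1nc(N(C)c2ccc([Se]C#N)c(Cl)c2)c2ccccc2n1` gives 12 nM and compound 3 `C[Se]c1ccc(N(C)c2nc(C3CC3)nc3ccccc23)cc1` gives 32 nM. Compound 2 `COc1ccc(N(C)c2nc(C)nc3ccccc23)cc1C(=O)NCC[Se]C#N` gives 179 nM, the highest number of the three and beyond the scatter from both of the others. Compound 4 `COc1ccc(N(C)c2nc(C)nc3ccccc23)cc1OCCC[Se]C#N` has not yet been measured; it differs from compound 2 in one place: a group of 7 heavy atoms (4 carbon, 1 nitrogen, 1 oxygen, 1 selenium; no ring) in place of a group of 8 heavy atoms (4 carbon, 2 nitrogen, 1 oxygen, 1 selenium; no ring), on an aromatic carbon The change sits on an aromatic carbon of a six-membered aromatic ring of carbon only, ortho to a methoxy group and meta to a large group. Among the measured compounds shown here, no measured pair of the series isolates such a change, so no step size is known. For compound 4 the expected number is 130 nM, with a range of 50 nM to 350 nM, a step from compound 2 to compound 4 of a 1.4-fold lower number from compound 2 to compound 4 (0.14 log units; within the scatter) that is estimated to stay within the scatter.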

Compound 4, half-maximal inhibitory concentration: 1040 nM
Beside the measured number, compound 4's estimate is 8.0-fold (0.90 log units) below it; measured number outside the range, above it.
By their numbers in this assay, from the lowest: compound 1; then compound 3; then compound 2; then compound 4.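

In this assay the aromatic carbon ortho to a methoxy group does not treat these two selenium-bearing chains alike: the swap gives a 5.8-fold higher number from compound 2 to compound 4 (0.76 log units; beyond the scatter), and inhibition weakens. The position therefore responds to the make-up of the group and not only to its size, though this rests on a single pair. No measurement here accounts for the step.

From the compounds shown here alone, whether the lost hydrogen-bond donor, the lost double bond or the altered chain matters most stays open. So does how a longer chain or a carboxylic acid on this carbon would read.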